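Ethyl in Place of Trifluoromethyl: A Small Step Expected

A few compounds are considered here, and "the series" means these few. Any claim that something is new, unique, unknown or untested is made for them only; others in the source may bear on it.

Compound 1 `Cc1ccccc1C(=O)Nc1cccc(-c2oc3cc(-c4ccc(F)cc4)ccc3c(=O)c2O)c1` and compound 2 `O=C(Nc1cccc(-c2oc3cc(-c4ccc(F)cc4)ccc3c(=O)c2O)c1)c1ccc(C(F)(F)F)cc1` share one core and differ only in the group attached to the carbonyl carbon. In a functional assay on A549 cells (Homo sapiens) for antiproliferative activity, read by CCK-8 assay, with a stated time of 72 h (a lower number here means a stronger inhibitor, a higher number a weaker inhibitor), compound 1 gives 17600 nM, and compound 2 gives 19400 nM. The step of a 1.1-fold higher number from compound 1 to compound 2 (0.04 log units; within the scatter) lies within the scatter, so compound 2 holds the highest of the two numbers shown while its gap to compound 1 carries no weight.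

Compound 3 `CCc1ccc(C(=O)Nc2cccc(-c3oc4cc(-c5ccc(F)cc5)ccc4c(=O)c3O)c2)cc1` differs from compound 2 by ethyl in place of trifluoromethyl on an aromatic carbon. Going by the values given here, only one measured step bears on a change at this carbon, the step from compound 1 to compound 2, and it was within the scatter; no other measured pair touches this position. On that basis compound 3 is expected to show no step beyond the scatter in this assay, that is a 1.1-fold lower number from compound 2 to compound 3 (0.03 log units; within the scatter). Compound 3 is therefore estimated at 18000 nM, with a range from 8000 nM to 40000 nM.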

Compound 3, half-maximal inhibitory concentration: 18500 nM
Compound 3: the middle estimate sits 1.0-fold (0.01 log units) below what was measured; low and high end bracket the measured number.
By their numbers in this assay, from the lowest: compounds 1, 3 and 2 (each within the scatter of the next).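

In this assay, ethyl in place of trifluoromethyl on this aromatic carbon gives a 1.0-fold lower number from compound 2 to compound 3 (0.02 log units; within the scatter), so a second substituent at this carbon now joins the earlier change of aryl group in producing no step beyond the scatter. The comparison with the ortho-free 4-ethylphenyl group adds the same reading on the carbonyl carbon, with 4-ethylphenyl in place of 2-methylphenyl giving a 1.1-fold higher number from compound 1 to compound 3 (0.02 log units; within the scatter), and all three aryl amides therefore stand within the scatter of one another. Nothing available explains this absence of a measurable difference.

The compounds shown leave open whether an amine, a carboxylic acid or a longer chain on this aromatic carbon would give a step beyond the scatter. They also leave open whether any change at this end of the molecule can move the number at all.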